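The source may report more compounds than this note shows. Statements on the series, on what has been measured and on what is new or still open speak of the compounds shown alone.

Working notes on the series

Compound 1 `CCC1(Cc2ccccc2)OS(=O)(=O)C=C1OCC(=O)OC` stands at a limit of an ADME assay on HEL cells (Homo sapiens) for cytotoxicity, with a stated time of 3 days; on this read-out higher numbers stand for lower toxicity in this test and lower numbers for higher toxicity in this test: in this assay compound 1 gives > 400000 nM, which is a limit of the assay and not a number. Compound 3 `CCC1(Cc2ccccc2)OS(=O)(=O)C=C1OCc1ccccc1` also stands at a limit, giving >= 50000 nM in this assay. Compound 2 `O=S1(=O)C=C(OCc2ccccc2)C(Cc2ccccc2)(Cc2ccccc2)O1` gives 200000 nM in this assay. The step that the two limits leave unreadable from compound 1 to compound 3 cannot be read because both ends sit at limits, the limit of > 400000 nM in this assay, at which 1 of the 3 values shown sits, and (the limit of >= 50000 nM in this assay, at which 1 of the 3 values shown sits); the step that the limit leaves unreadable from compound 2 to compound 3 is likewise unreadable.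

Compound 4 `CCC1(Cc2ccccc2)OS(=O)(=O)C=C1OCc1ccc(Cl)cc1` has not been measured. It differs from compound 1 by 4-chlorophenyl in place of methoxycarbonyl on a saturated chain carbon bound to an oxygen on an unsaturated carbon. Among the compounds with values here, the closest measured step is the one from compound 1 to compound 3, whose size is not readable, so no direction can be taken from it; compound 2 is the only number without a limit in the set. Compound 4 is therefore expected to sit near that number, and its value in this assay is estimated at 100000 nM (range 20000 nM to 400000 nM), meaning an expected step of an at least 4.0-fold lower number from compound 1 to compound 4 (0.60 log units; beyond the scatter), with a fair chance that only a limit is reported again.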

Compound 4, minimum cytotoxic concentration: >= 50000 nM
Compound 4: only a limit was reported; the forecaster's own chance of this, stated with the estimate: 45%; the middle value lies beyond the limit too.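

In this assay compound 4 gives >= 50000 nM, which is a limit of the assay and not a number. The steps to compound 4 from compound 1 and from compound 3 therefore cannot be read. The compounds shown leave open whether chloro in place of hydrogen on an aromatic carbon changes this read-out at all.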